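The compounds below may be only part of what the source reports. "The series", "measured", "known", "first", "only" and "open" are said of these compounds alone.

Measured in an ADME assay on BJ cells (Homo sapiens) for cytotoxicity, with a stated time of 72 h; a higher number here means that more compound is needed for the effect, a lower number that less compound is needed:
Compound 1 `Cc1cc(NC(=O)Nc2cccc([N+](=O)[O-])c2)c2ccccc2n1`: > 25000 nM, a limit
Compound 2 `COC(=O)c1cccc(NC(=O)Nc2cc(C)nc3ccccc23)c1`: 21000 nM

Within the data shown here, compound 2, at 21000 nM, holds the only number so far in this assay. Compound 1 stands at a limit, as the limit of > 25000 nM in this assay, at which 1 of the 2 values shown sits, shows.

Compound 3 `Cc1cc(NC(=O)Nc2cccc(N(C)C)c2)c2ccccc2n1` follows from compound 2 by dimethylamino in place of methoxycarbonyl on an aromatic carbon. Among the measured compounds shown here, the only measured step bearing on this change is another swap on an aromatic carbon, an at least 1.1-fold lower number from compound 1 to compound 2 (0.07 log units; that floor lies within the scatter). No change beyond the scatter is therefore expected, though one measured step is thin support. The expected step is a 1.2-fold lower number from compound 2 to compound 3 (0.07 log units; within the scatter). For compound 3 the estimated value is 18000 nM, with an expected range of 7000 nM to 30000 nM.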

Compound 3, half-maximal effective concentration: > 25000 nM
Compound 3: only a limit was reported; the forecaster's own chance of this, stated with the estimate: 35%; middle value at least 1.3-fold (0.14 log units) from the limit.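

Compound 3 gives > 25000 nM in this assay, which is a limit and not a number. Dimethylamino in place of methoxycarbonyl gives an at least 1.1-fold higher number from compound 2 to compound 3 (0.07 log units; that floor lies within the scatter), so this position has yet to show a change beyond the scatter. The step from compound 1 to compound 3 cannot be read, and the limit now holds most of the values: the limit of > 25000 nM in this assay, at which 2 of the 3 values shown sit.

On these data alone, whether a carboxylic acid or a primary amine at this position would give a number clearly apart from that of compound 2 stays open. Also open, as far as these compounds go, is whether compound 1 and compound 3 differ at all.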